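A few compounds are considered here, and "the series" means these few. Any claim that something is new, unique, unknown or untested is made for them only; others in the source may bear on it.

Measured compounds in an assay for inhibition of Amine oxidase [flavin-containing] B (Rattus norvegicus), with a stated time of 60 min; on this read-out higher numbers stand for weaker inhibition and lower numbers for stronger inhibition:
compound 1, `CCNC(=S)N1N=C(c2ccc(C)cc2)CC1c1ccc[nH]1`: 369000 nM
compound 2, `CCCNC(=S)N1N=C(c2ccc(C)cc2)CC1c1ccc[nH]1`: 389000 nM
compound 3, `CCNC(=S)N1N=C(c2ccc(OC)cc2)CC1c1ccc[nH]1`: 22100 nM

Among these three, compound 3 gives the lowest number in this assay; its nearest neighbour is compound 1, and the change from compound 1 to compound 3 reads a 17-fold lower number from compound 1 to compound 3 (1.22 log units; beyond the scatter), a large step. Compound 4, `CCCNC(=S)N1N=C(c2ccc(OC)cc2)CC1c1ccc[nH]1`, is not yet measured and differs from compound 3 by methyl in place of hydrogen on a saturated chain carbon, two bonds along the chain from an amide-type nitrogen. Among the compounds with values here, the one measured step that bears on this change is the one from compound 1 to compound 2, which reads a 1.1-fold higher number from compound 1 to compound 2 (0.02 log units; within the scatter). On that basis the step from compound 3 to compound 4 is expected to read a 1.1-fold higher number from compound 3 to compound 4 (0.04 log units; within the scatter), nothing beyond the scatter. Compound 4 is therefore estimated at 24000 nM, with a range from 10000 nM to 60000 nM.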

Compound 4, half-maximal inhibitory concentration: 29100 nM
Beside the measured number, compound 4's estimate is 1.2-fold (0.08 log units) below it, within the range that was stated.
By their numbers in this assay, from the lowest: compounds 3 and 4 (each within the scatter of the next); then compounds 1 and 2 (each within the scatter of the next).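

In this assay, ethylamino to propylamino now reads a 1.3-fold higher number from compound 3 to compound 4 (0.12 log units; within the scatter), so this change stays within the scatter on the core of compound 3 as well as on the core of compound 1: the same change on two cores in this assay, a 1.1-fold higher number (0.02 log units; within the scatter) from compound 1 to compound 2 and a 1.3-fold higher number (0.12 log units; within the scatter) from compound 3 to compound 4, 1.2-fold (0.10 log units) apart, within the scatter of two such steps. Methoxy in place of methyl on an aromatic carbon, read a second time as a 13-fold lower number from compound 2 to compound 4 (1.13 log units; beyond the scatter), keeps its large size with the propylamino group in place: the same change on two cores in this assay, a 17-fold lower number (1.22 log units; beyond the scatter) from compound 1 to compound 3 and a 13-fold lower number (1.13 log units; beyond the scatter) from compound 2 to compound 4, 1.2-fold (0.10 log units) apart, within the scatter of two such steps. Across these four compounds, neither change alters the reading of the other.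

On these data alone, it remains open whether a longer chain or a carboxylic acid in place of propyl would stay within the scatter. As far as these compounds go, it is also open whether ethoxy or chloro in place of methoxy on that aromatic carbon would give a lower number.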